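Shortened carboxylic acid chain on a pyridyl-phenyl alkene core

A few compounds are considered here, and "the series" means these few. Any claim that something is new, unique, unknown or untested is made for them only; others in the source may bear on it.

Measured so far:
compound 1 `CSC(CCC/C=C(\c1ccccc1)c1cccnc1)C(=O)O`, 30 nM
compound 2 `O=C(O)CCCCCCCCC/C=C(\c1ccccc1)c1cccnc1`, 55 nM

In an assay (Equus caballus) for inhibition of Thromboxane-A synthase (Homo sapiens), using microsomes (on this read-out lower numbers stand for stronger inhibition and higher numbers for weaker inhibition), compound 1 gives 30 nM and compound 2 gives 55 nM. On these two numbers compound 2 stands with its value close to that of compound 1, the gap lying within the usual scatter. Compound 3 `CC(C)(CCCC/C=C(\c1ccccc1)c1cccnc1)C(=O)O` differs from compound 2 by 1-carboxy-1-methylethyl in place of 5-carboxypentyl on a saturated chain carbon, four bonds along the chain from a double-bonded chain carbon. No comparable change has been measured here. For compound 3 a step no larger than the scatter is expected, as a 1.1-fold higher number from compound 2 to compound 3 (0.04 log units; within the scatter). In this assay compound 3 is estimated at 60 nM, with a range from 15 nM to 250 nM.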

Compound 3, half-maximal inhibitory concentration: 45 nM
Beside the measured number, compound 3's estimate is 1.3-fold (0.12 log units) above it; the measured number falls inside the stated range.
By their numbers in this assay, from the lowest: compounds 1, 3 and 2 (each within the scatter of the next).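

In this assay, 1-carboxy-1-methylethyl in place of 5-carboxypentyl gives a 1.2-fold lower number from compound 2 to compound 3 (0.09 log units; within the scatter) and so shows that this position accepts the exchange with no readable shift, even with the two methyl-bearing chain carbon ending in the acid replacing the longer chain. With 2-carboxy-2-methylpropyl in place of carboxy(methylsulfanyl)methyl there is a 1.5-fold higher number from compound 1 to compound 3 (0.18 log units; within the scatter) and again no readable difference. Nothing available here accounts for how closely these values sit. The compounds shown leave open whether an amine or an ester in place of the carboxylic acid would hold the number in this range.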